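A few compounds are considered here, and "the series" means these few. Any claim that something is new, unique, unknown or untested is made for them only; others in the source may bear on it.

Working notes on the series. In a functional assay on HepG2 cells (Homo sapiens) for antiproliferative activity, read by MTT assay (on this read-out higher numbers stand for weaker inhibition and lower numbers for stronger inhibition), compound 3 `CC1(C)CCc2c(ccc(C(=O)/C=C/c3ccc(OCc4cn(-c5ccc(Cl)cc5)nn4)cc3)c2O)O1` gives 102000 nM. Compound 1 `CCc1ccccc1-n1cc(COc2ccc(/C=C/C(=O)c3cc4c(cc3O)OC(C)(C)CC4)cc2)nn1` gives 115000 nM and compound 2 `Cc1ccc(-n2cc(COc3ccc(/C=C/C(=O)c4cc5c(cc4O)OC(C)(C)CC5)cc3)nn2)cc1Br` gives 117000 nM. All three values lie within the scatter of one another, so compound 3 holds no distinct place among them.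

Compound 4 `Cc1ccc(-n2cc(COc3ccc(/C=C/C(=O)c4ccc5c(c4O)CCC(C)(C)O5)cc3)nn2)cc1Br` keeps the core of compound 3 and carries 3-bromo-4-methylphenyl in place of 4-chlorophenyl on an aromatic nitrogen of a five-membered aromatic ring with 3 nitrogen: 3-bromo-4-methylphenyl in place of 4-chlorophenyl on an aromatic nitrogen.

Going by the values given here, only one measured step bears on this change, and only indirectly. It brings in the same 3-bromo-4-methylphenyl, but it replaces 2-ethylphenyl, and on a core that differs from that of compound 3. That step is a 1.0-fold higher number from compound 1 to compound 2 (0.01 log units; within the scatter), which stays within the scatter. Among the compounds with values here, no measured step replaces 4-chlorophenyl, so the evidence is thin. Even so, nothing in the three values points to a step beyond the scatter in this assay, and no direction is expected. The estimated step is a 1.1-fold higher number from compound 3 to compound 4 (0.03 log units; within the scatter). For compound 4 the expected value is 110000 nM, with an estimated range from 60000 nM to 190000 nM.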

Compound 4, half-maximal inhibitory concentration: 110000 nM
The estimate for compound 4 equals the measured number at the digits printed; the measured number falls inside the stated range.
By their numbers in this assay, from the lowest: compounds 3, 4, 1 and 2 (each within the scatter of the next).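

In this assay, going by these compounds alone, the step on the core of compound 3 (a 1.1-fold higher number from compound 3 to compound 4 (0.03 log units; within the scatter)) is the first reading of a replacement of 4-chlorophenyl on the aromatic nitrogen of the five-membered ring. Within the data shown here, the only earlier step at this position (a 1.0-fold higher number from compound 1 to compound 2 (0.01 log units; within the scatter)) started from 2-ethylphenyl on the core of compound 1, so 3-bromo-4-methylphenyl has now entered on two different cores, in place of two different groups, and both steps stay within the scatter; neither step goes against this, though two steps make a narrow base. No measurement on hand speaks to why the number holds at this level after this change.

The compounds shown leave open whether a group of another kind on the phenyl ring at this position, such as an amine or a carboxylic acid, would move the number beyond the scatter. Also open, going by these compounds, is how 4-chlorophenyl and 2-ethylphenyl compare with each other on a single core, and whether either of them carries over unchanged from one core to the other.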